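Lengthening the Chain End: Nitrile to Primary Amide

A few compounds are considered here, and "the series" means these few. Any claim that something is new, unique, unknown or untested is made for them only; others in the source may bear on it.

Three compounds share one core. Compound 1 `NCCCCc1c[nH]c2c(F)cccc12` carries a short chain ending in an amine; in an assay on isolated protein (urine) for inhibition of Myeloperoxidase (Homo sapiens), with a stated time of 5 min (a higher number here means a weaker inhibitor, a lower number a stronger inhibitor), compound 1 gives 6 nM. Compound 2 `N#CCCCc1c[nH]c2ccc(F)cc12` carries a chain ending in a nitrile, and in this assay compound 2 gives 63 nM. Of the two numbers, compound 2 stands higher, and the gap to compound 1 is beyond the usual scatter, so compound 2 is the weaker inhibitor of the pair. Compound 3 `N#CCCCc1c[nH]c2ccc(C(=O)O)cc12`, with a carboxylic acid on the ring instead of the fluorine, is reported in this assay as "not active" (no number reported), without a number.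

Compound 4 `NC(=O)CCCCc1c[nH]c2ccc(F)cc12` has not yet been measured. It differs from compound 2 by one change: carbamoylmethyl in place of cyano on a saturated chain carbon, three bonds along the chain from an aromatic carbon. Within the data shown here, no measured pair shows this kind of change, so nothing can be read off directly. Compound 1 shows that a donor-bearing chain end can sit well in this assay, which argues against a large loss. The step of a 1.3-fold higher number from compound 2 to compound 4 (0.10 log units; within the scatter) is expected to be modest and within the scatter. For compound 4 in this assay the estimate is 80 nM, with a likely range from 25 nM to 300 nM.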

Compound 4, half-maximal inhibitory concentration: 39 nM
For compound 4 the middle estimate is 2.1-fold (0.31 log units) above the measured one, and the stated range covers the measured number.
By their numbers in this assay, from the lowest: compound 1; then compounds 4 and 2 (each within the scatter of the next).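

In this assay, putting carbamoylmethyl in place of cyano on a saturated chain carbon, three bonds along the chain from an aromatic carbon, gives a 1.6-fold lower number from compound 2 to compound 4 (0.21 log units; within the scatter), so the two compounds cannot be told apart in this assay. Among these compounds, this is the first pair in the set that differs in one place, and it shows that the chain end can change from a nitrile to a primary amide, which is a larger group and brings in a hydrogen-bond donor, without a measurable shift in the number. Nothing measured here explains why the number holds steady across this change.

An amine on the chain of compound 4 remains an open case, as compound 1 carries an amine but differs from compound 4 in more than one place, so it cannot show what that group alone would do. Also open, on these data alone, are a carboxylic acid at the chain end and a longer chain, either of which would show how far this position accepts change before the number moves beyond the scatter.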